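Adding chloro to a compound at the assay limit

The compounds below may be only part of what the source reports. "The series", "measured", "known", "first", "only" and "open" are said of these compounds alone.

Compound 1 (`CC1CCN(C2CCN(S(=O)(=O)c3cccc(C(F)(F)F)c3)CC2)CC1`) gives > 5000 nM in an ADME assay on HCT-116 cells (Homo sapiens) for cytotoxicity, read by CellTiter-Glo, with a stated time of 72 h (on this read-out higher numbers stand for weaker inhibition and lower numbers for stronger inhibition), and this value is a limit rather than a number. Compound 2 (`CC1CCN(C2CCN(S(=O)(=O)c3cccc(Br)c3)CC2)CC1`) gives > 5000 nM in this assay, which is also a limit. Both compounds therefore sit at the same boundary: the limit of > 5000 nM in this assay, at which 2 of the 2 values shown sit. Among the measured compounds shown here, the one measured step, a step that the two limits leave unreadable from compound 1 to compound 2, has no readable size, and it concerns a different change on the aromatic ring.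

Compound 3 (`CC1CCN(C2CCN(S(=O)(=O)c3ccc(Cl)c(C(F)(F)F)c3)CC2)CC1`) differs from compound 1 by chloro in place of hydrogen on an aromatic carbon, ortho to a trifluoromethyl group and para to a large group. For the measured compounds named here, with a step that the two limits leave unreadable from compound 1 to compound 2 as the only guide, no step beyond the scatter is expected. The expected step is a step that the limit leaves unreadable from compound 1 to compound 3. For compound 3 the estimated value in this assay is 6000 nM, with an expected range from 2500 nM to 12000 nM.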

Compound 3, half-maximal inhibitory concentration: > 5000 nM
Compound 3: no number, only a limit; the forecaster's own chance of this, stated with the estimate: 80%; the middle value does not contradict the limit.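

In this assay, among the compounds shown here, compound 3 gives > 5000 nM, which is a limit and not a number, and compound 1 also stands at a limit, so no step between them can be read. Compound 1, compound 2 and compound 3 leave open whether chloro in place of hydrogen on an aromatic carbon shifts this read-out at all, because all three share one boundary: the limit of > 5000 nM in this assay, at which 3 of the 3 values shown sit.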